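The source may report more compounds than this note shows. Statements on the series, on what has been measured and on what is new or still open speak of the compounds shown alone.

Measured so far:
compound 1 `COc1cc(Cc2nc3c(N)ncnc3n2CCCCCO)cc(OC)c1OC`, 84900000 nM
compound 2 `COc1cc(Cc2nc3c(N)ncnc3n2CC(C)CCCO)cc(OC)c1OC`, 8770000 nM
compound 3 `CCCCCn1c(Cc2cc(OC)c(OC)c(OC)c2)nc2c(N)nc(F)nc21`, 286000000 nM

All three numbers come from a functional assay on MCF7 cells (Homo sapiens) for cytotoxicity; on this read-out lower numbers stand for an effect already at smaller amounts and higher numbers for an effect only at larger amounts of compound. Compound 1 and compound 2 share a core; their difference is methyl in place of hydrogen on a saturated chain carbon bound to two saturated chain carbons, and the step is a 9.7-fold lower number from compound 1 to compound 2 (0.99 log units; beyond the scatter). Compound 3 has a different core; the difference between the two cores is not broken down here. The values of compound 1 and compound 3 show the higher number for compound 3, and compound 2 has the lowest of the three.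

Compound 4 `CCCCCCn1c(Cc2cc(OC)c(OC)c(OC)c2)nc2c(N)nc(F)nc21` is not yet measured. It differs from compound 3 by methyl in place of hydrogen on a saturated chain carbon, five bonds along the chain from an aromatic nitrogen. This is the same kind of change as from compound 1 to compound 2, not the same: there the methyl entered on a saturated chain carbon bound to two saturated chain carbons, here on a saturated chain carbon, five bonds along the chain from an aromatic nitrogen. The expectation for compound 4 rests on the direction of a 9.7-fold lower number from compound 1 to compound 2 (0.99 log units; beyond the scatter), with the size discounted since that step sits on another core. Compound 4 is expected at 100000000 nM, between 30000000 nM and 350000000 nM. The expected step is a 2.9-fold lower number from compound 3 to compound 4 (0.46 log units; beyond the scatter).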

Compound 4, half-maximal effective concentration: 112000000 nM
Estimate against measurement, compound 4: 1.1-fold (0.05 log units) below; low and high end bracket the measured number.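

In this assay the methyl change gives a 2.6-fold lower number from compound 3 to compound 4 (0.41 log units; beyond the scatter), so the direction seen on the core of compound 1 also appears on the core of compound 3, but the size does not carry over: the same change on two cores in this assay, a 9.7-fold lower number (0.99 log units; beyond the scatter) from compound 1 to compound 2 and a 2.6-fold lower number (0.41 log units; beyond the scatter) from compound 3 to compound 4, 3.8-fold (0.58 log units) apart, beyond the scatter of two such steps

This comparison rests on one pair per core, and the methyl enters at a different place in each: on a saturated chain carbon bound to two saturated chain carbons in compound 2, and on a saturated chain carbon, five bonds along the chain from an aromatic nitrogen, in compound 4. The effects of core and place therefore cannot be separated, and two pairs show neither a general rule for the series nor the origin of the gap in size.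

Going by these compounds, it remains open how a longer chain, or an amine or a carboxylic acid on the chain, would read on either core. The compounds shown also leave open whether the lower numbers on the core of compound 3 continue beyond compound 4 as the chain grows.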